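This account rests on a few compounds, and the source may have more. Where it says the series, first, only, none or still open, it means among the compounds named here.

Compound 1, `CNC(=O)c1cc(Oc2ccc(NC(=O)c3nn(-c4cccc(F)c4)c(=O)cc3C)cc2F)ccn1`: 9540 nM
Compound 2, `CNC(=O)c1cc(Oc2ccc(NC(=O)c3nn(-c4ccc(C)cc4)c(=O)cc3C)cc2F)ccn1`: 11500 nM
Compound 3, `Cc1cc(=O)n(-c2cccc(F)c2)nc1C(=O)Nc1ccc(Oc2ncnc3sccc23)c(F)c1`: 19500 nM

All three were tested in a functional assay on A549 cells (Homo sapiens) for cytotoxicity, read by MTT assay, with a stated time of 72 h; a lower number here means a stronger inhibitor, a higher number a weaker inhibitor. Compounds 1 and 2 share one core and differ in a single place: 4-methylphenyl in place of 3-fluorophenyl on an aromatic nitrogen. In this assay compound 1 gives 9540 nM and compound 2 gives 11500 nM. The step of a 1.2-fold higher number from compound 1 to compound 2 (0.08 log units; within the scatter) is small and sits within the usual scatter, so these two compounds cannot be told apart on this evidence.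

Compound 3 carries a different core. Its difference from compound 1 is a group of 9 heavy atoms (6 carbon, 2 nitrogen, 1 sulfur; one five-membered aromatic ring with 1 hetero atom, one six-membered aromatic ring with 2 hetero atoms) in place of a group of 10 heavy atoms (7 carbon, 2 nitrogen, 1 oxygen; one six-membered aromatic ring with 1 hetero atom), on an oxygen on an aromatic ring. In this assay compound 3 gives 19500 nM. The step of a 2.0-fold higher number from compound 1 to compound 3 (0.31 log units; beyond the scatter) is modest though beyond the scatter, while the gap between compound 3 and compound 2 lies within it.

Compound 4, `Cc1ccc(-n2nc(C(=O)Nc3ccc(Oc4ncnc5sccc45)c(F)c3)c(C)cc2=O)cc1`, has not yet been measured. It relates to compound 3 as compound 2 relates to compound 1: 4-methylphenyl in place of 3-fluorophenyl on an aromatic nitrogen. The surroundings of the place are described in the same words in both pairs, so this is the same change. The step from compound 3 to compound 4 is expected to be a 1.1-fold higher number from compound 3 to compound 4 (0.05 log units; within the scatter), which is as small as the earlier one, because the same change between compound 1 and compound 2 gave only a 1.2-fold higher number from compound 1 to compound 2 (0.08 log units; within the scatter). Compound 4 is therefore estimated to give 22000 nM in this assay, with a likely range from 10000 nM to 48000 nM.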

Compound 4, half-maximal inhibitory concentration: > 40000 nM
Compound 4: no number, only a limit (the forecaster's own chance of this, stated with the estimate: 15%); middle value at least 1.8-fold (0.25 log units) away from the limit.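

In this assay compound 4 gives > 40000 nM, which is a limit of the assay and not a number: the limit of > 40000 nM in this assay, at which 1 of the 4 values shown sits.

On the core of compound 3, 4-methylphenyl in place of 3-fluorophenyl gives an at least 2.0-fold higher number from compound 3 to compound 4 (0.31 log units; beyond the scatter), whereas the same change on the core of compound 1 gives a 1.2-fold higher number from compound 1 to compound 2 (0.08 log units; within the scatter), so these compounds show neither that the change carries over unaltered nor that its size depends on the core: the same change on two cores in this assay, a 1.2-fold higher number (0.08 log units; within the scatter) from compound 1 to compound 2 and an at least 2.0-fold higher number (0.31 log units; beyond the scatter) from compound 3 to compound 4; the limit leaves it open whether they differ The change of the group on the oxygen on an aromatic ring points the same way with either group on the aromatic nitrogen, with a 2.0-fold higher number from compound 1 to compound 3 (0.31 log units; beyond the scatter) and an at least 3.4-fold higher number from compound 2 to compound 4 (0.54 log units; beyond the scatter), but here too no difference in size can be claimed: the same change on two cores in this assay, a 2.0-fold higher number (0.31 log units; beyond the scatter) from compound 1 to compound 3 and an at least 3.4-fold higher number (0.54 log units; beyond the scatter) from compound 2 to compound 4; the limit leaves it open whether they differ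

The compounds shown leave open how far compound 4 lies past its limit, and so how large the step to it really is. They also leave open whether a plain phenyl or a 4-chlorophenyl on the same aromatic nitrogen would follow the pattern of the core of compound 1 or that of the core of compound 3.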